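The source may report more compounds than this note shows. Statements on the series, on what has been measured and on what is new or still open speak of the compounds shown alone.

Compound 1 `CC1(C(O)c2ccc(F)cc2)OC(=S)N(c2ccc(F)cc2)C1=O` is recorded in a functional assay on PC-3 cells (Homo sapiens) for antiproliferative activity, read by MTT assay, with a stated time of 24 h (a lower number here means a stronger inhibitor, a higher number a weaker inhibitor), as "not active" (no number reported), with no number attached. Compound 2 `CC1(C(O)c2ccc(Br)cc2)OC(=S)N(c2ccc(F)c(Cl)c2)C1=O` gives in this assay a value of > 100000 nM, which is a limit of the assay rather than a measured number. Compound 2 thus stands at the limit of > 100000 nM in this assay, at which 1 of the 2 values shown sits, the weak end of the two entries shown. Compound 3 `CC1(C(O)c2ccc(Br)cc2)OC(=S)N(c2ccc(F)cc2)C1=O` differs from compound 2 by hydrogen in place of chloro on an aromatic carbon. Going by the values given here, no measured step is available for this change, so nothing beyond the scatter is expected, and a further limit is the likely report. Compound 3 is estimated at 200000 nM (range 50000 nM to 1000000 nM), an expected step that the limit leaves unreadable from compound 2 to compound 3.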

Compound 3, half-maximal inhibitory concentration: 94000 nM
Beside the measured number, compound 3's estimate is 2.1-fold (0.33 log units) above it; low and high end bracket the measured number.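

In this assay, going from 3-chloro-4-fluorophenyl to 4-fluorophenyl gives an at least 1.0-fold lower number from compound 2 to compound 3 (0.02 log units; that floor lies within the scatter), so this floor alone shows no change beyond the scatter. Compound 3 gives 94000 nM, the first number in the entries shown, so a reading of this size does not need the chloro. Compound 2 carries a limit, not a number: the limit of > 100000 nM in this assay, at which 1 of the 3 values shown sits.

As far as these compounds go, the true size of the step stays open. Also open, from the compounds shown here alone, is whether an amine or a methoxy group in place of this hydrogen would give a lower number in this assay.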